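This account rests on a few compounds, and the source may have more. Where it says the series, first, only, none or still open, it means among the compounds named here.

In a functional assay on A549 cells (Homo sapiens) for cytotoxicity, read by MTT assay, with a stated time of 72 h (on this read-out lower numbers stand for stronger inhibition and higher numbers for weaker inhibition), compound 1 (`Cn1ccc2c(Oc3ccc(NC(=O)c4cc5cccnc5n(-c5ccccc5)c4=O)cc3)ncnc21`) gives 66200 nM and compound 2 (`Cn1ccc2c(Oc3ccc(NC(=O)c4cc5cccnc5n(-c5ccc(Cl)cc5)c4=O)cc3)ncnc21`) gives 75500 nM while compound 3 (`Cn1ccc2c(Oc3ccc(NC(=O)c4cc5cccnc5n(-c5ccccc5)c4=O)cc3F)ncnc21`) gives 63200 nM on the same read-out. Compound 3 therefore stands level with the other two: its gaps to compound 1 and to compound 2 both lie within the scatter, and no order can be drawn among the three.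

Compound 4 (`Cn1ccc2c(Oc3ccc(NC(=O)c4cc5cccnc5n(-c5ccc(Cl)cc5)c4=O)cc3F)ncnc21`) differs from compound 3 by chloro in place of hydrogen on an aromatic carbon, which reads as phenyl to 4-chlorophenyl. The same replacement has been measured once (a 1.1-fold higher number from compound 1 to compound 2 (0.06 log units; within the scatter)) and that step is the direct precedent. The fluoro replacement (a 1.0-fold lower number from compound 1 to compound 3 (0.02 log units; within the scatter)) is the other measured step, and it also stays within the scatter. For the measured compounds named here, no compound yet shows how the two replacements behave together. The expectation rests on compound 2 and its value of 75500 nM in the scatter of compound 1. The expected step is a 1.1-fold higher number from compound 3 to compound 4 (0.06 log units; within the scatter) and no move beyond the scatter is foreseen in this assay for this pair. For compound 4 the estimate is 72000 nM with an expected range (45000 nM to 110000 nM).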

Compound 4, half-maximal inhibitory concentration: 55500 nM
The estimate for compound 4 lay 1.3-fold (0.11 log units) above the measured number, within the range that was stated.
By their numbers in this assay, from the lowest: compounds 4, 3, 1 and 2 (each within the scatter of the next).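

With compound 4 the phenyl to 4-chlorophenyl change can be read on a second core in this assay, where it gives a 1.1-fold lower number from compound 3 to compound 4 (0.06 log units; within the scatter), and the two readings of the change agree: the same change on two cores in this assay, a 1.1-fold higher number (0.06 log units; within the scatter) from compound 1 to compound 2 and a 1.1-fold lower number (0.06 log units; within the scatter) from compound 3 to compound 4, 1.3-fold (0.11 log units) apart, within the scatter of two such steps

The fluoro replacement can now also be read on the 4-chlorophenyl core, where it gives a 1.4-fold lower number from compound 2 to compound 4 (0.13 log units; within the scatter), and its two readings agree as well: the same change on two cores in this assay, a 1.0-fold lower number (0.02 log units; within the scatter) from compound 1 to compound 3 and a 1.4-fold lower number (0.13 log units; within the scatter) from compound 2 to compound 4, 1.3-fold (0.11 log units) apart, within the scatter of two such steps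

Neither replacement moves the number beyond the scatter on either core, and compound 4, which carries both, gives no sign that the two act together on this read-out.

On these data alone, it remains open whether a group other than chloro on that aromatic carbon, such as an amine, a carboxylic acid or a longer chain, would give a step beyond the scatter. Since each of the four numbers lies within the scatter of the next, the compounds shown also leave open which part of the shared core, if any, governs the read-out in this assay.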